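Methoxy for methyl on a cytotoxicity baseline

The source may report more compounds than this note shows. Statements on the series, on what has been measured and on what is new or still open speak of the compounds shown alone.

In an ADME assay on HFF cells (Homo sapiens) for cytotoxicity, with a stated time of 72 h (a lower number here means that less compound is tolerated, a higher number that more compound is tolerated), compound 1 `CC(C)(C)c1ccc(C(=O)Nc2cc(Cl)c(Br)nc2C(=O)O)cc1` gives > 50000 nM as a limit of the assay and not a number. Going by the values given here, compound 2 `Cc1ccc(C(=O)Nc2cc(Cl)cnc2C(=O)O)cc1` gives 18200 nM as the only actual number so far. Compound 3 `COc1ccc(C(=O)Nc2cc(Cl)cnc2C(=O)O)cc1` is not yet measured and has methoxy in place of methyl on an aromatic carbon with the group para to a large group. Among the compounds with values here, no measured pair isolates this change. The estimated 1.1-fold higher number from compound 2 to compound 3 (0.04 log units; within the scatter) is expected to stay within the usual scatter in this assay with no direction favoured. For compound 3 the estimate is 20000 nM with 9000 nM to 45000 nM as its expected range.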

Compound 3, half-maximal cytotoxic concentration: > 50000 nM
Compound 3: a limit, no number; the forecaster's own chance of this, stated with the estimate: 15%; middle value at least 2.5-fold (0.39 log units) from the limit.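

In this assay, methoxy in place of methyl on an aromatic carbon, para to a large group, gives an at least 2.7-fold higher number from compound 2 to compound 3 (0.43 log units; beyond the scatter). Going by these compounds alone, this is the only step that isolates a change at this position, and it shows that the read-out responds to this swap beyond the scatter. The step is a lower bound and not a size, because the result for compound 3 is a limit of the assay and not a number: the limit of > 50000 nM in this assay, at which 2 of the 3 values shown sit.

The compounds shown leave open how far the true value of compound 3 lies from that of compound 2. They also leave open whether an ethoxy group or an amine at this place would give a similar step.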